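Sulfonamide series: removing the acetyl from the amino nitrogen

The source may hold more compounds than are shown below. What is called first, only, known or untested is meant among the compounds shown, and "the series" means these compounds.

Measured in a functional assay on U-87MG ATCC cells (Homo sapiens) for antiproliferative activity, read by MTT assay, with a stated time of 48 h; on this read-out lower numbers stand for stronger inhibition and higher numbers for weaker inhibition:

compound 1 `COc1ncc(-c2ccn3nc(NC(C)=O)nc3c2)cc1NS(=O)(=O)c1ccc(C)cc1`: 2030 nM
compound 2 `COc1ncc(-c2ccn3nc(NC(C)=O)nc3c2)cc1NS(=O)(=O)c1ccc(F)cc1`: 2410 nM

Compound 2 carries the higher of the two numbers in this assay, but the step of a 1.2-fold higher number from compound 1 to compound 2 (0.07 log units; within the scatter) is within the scatter, so the two compounds cannot be ordered against each other on this read-out.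

Compound 3 `COc1ncc(-c2ccn3nc(N)nc3c2)cc1NS(=O)(=O)c1ccc(F)cc1` is the next compound to be measured. It differs from compound 2 by hydrogen in place of acetyl on a nitrogen on an aromatic ring; cut one bond further out, the same difference reads acetamido to amino. For the measured compounds named here, the single measured step concerns the fluoro-for-methyl exchange on the sulfonyl aryl and does not touch the acetyl, so nothing measured bears on the present change. The expectation for compound 3 therefore rests only on the value of compound 2 in this assay, and the range must be wide.

Compound 3 is expected to give about 2500 nM in this assay, within roughly 700 nM to 9000 nM. This expected step a 1.0-fold higher number from compound 2 to compound 3 (0.02 log units; within the scatter) is no more than a placeholder until the measurement is in hand.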

Compound 3, half-maximal inhibitory concentration: 1770 nM
Beside the measured number, compound 3's estimate is 1.4-fold (0.15 log units) above it, and the stated range covers the measured number.
By their numbers in this assay, from the lowest: compounds 3, 1 and 2 (each within the scatter of the next).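

Read in this assay the exchange of acetamido for amino gives a 1.4-fold lower number from compound 2 to compound 3 (0.13 log units; within the scatter) and so leaves the two compounds without an order on this read-out. For the compounds shown here, this is the first measured change at the nitrogen on the aromatic ring, and it shows that, with fluoro on the sulfonyl aryl, the acetyl can be replaced by hydrogen without a step beyond the scatter. Nothing at hand offers an explanation for the size of this step.

Going by these compounds alone, whether a different group on this nitrogen, such as a butanoyl chain, a benzoyl or a simple methyl, would give a step beyond the scatter remains open, since the only exchange read here is acetyl for hydrogen. Also open, as far as these compounds go, is whether the amino and acetamido forms would still read alike with methyl on the sulfonyl aryl, or with a larger group there, such as a morpholine or a carboxylic acid.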